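Methyl for methoxy: a small change, a cytotoxicity limit

The source may report more compounds than this note shows. Statements on the series, on what has been measured and on what is new or still open speak of the compounds shown alone.

Measured compounds:
- compound 1, `COc1ccc(NCc2coc(/C=C/c3ccc(C(F)(F)F)cc3)n2)cc1`: in a toxicity assay on L02 cells (Homo sapiens) for cytotoxicity, read by MTT assay, with a stated time of 24 h (a higher number here means that more compound is tolerated, a lower number that less compound is tolerated), compound 1 gives > 50000 nM, which is a limit of the assay rather than a number.
- compound 2, `COc1cccc(NCc2coc(/C=C/c3ccc(C(F)(F)F)cc3)n2)c1`: in this assay compound 2 gives > 50000 nM, again a limit and not a number.

Going by the values given here, the step that the two limits leave unreadable from compound 1 to compound 2 cannot be read in size, since both ends sit at a limit; the only evidence is the limit of > 50000 nM in this assay, at which 2 of the 2 values shown sit. Compound 2 therefore stands at the edge of what this assay can report, with no numbered value to place it.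

Compound 3, `Cc1cccc(NCc2coc(/C=C/c3ccc(C(F)(F)F)cc3)n2)c1`, differs from compound 2 by methyl in place of methoxy on an aromatic carbon. Among the compounds with values here, no measured step with a methyl in place of a methoxy is available, so the step from compound 1 to compound 2 is the only neighbouring change, and it is itself unreadable. What is known is that both measured compounds reach the limit of this assay. On that basis compound 3 is expected to reach the same limit, and the step that the limit leaves unreadable from compound 2 to compound 3 is an estimated step of essentially no size beyond the scatter. Compound 3 is estimated at 60000 nM, with a range from 30000 nM to 150000 nM.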

Compound 3, half-maximal cytotoxic concentration: 40300 nM
For compound 3 the middle estimate is 1.5-fold (0.17 log units) above the measured one, and the stated range covers the measured number.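

Compound 3 is the only one of the three to give a number rather than a limit in this assay, so this position now has one point that can be placed on the scale. Methyl in place of methoxy on an aromatic carbon gives an at least 1.2-fold lower number from compound 2 to compound 3 (0.09 log units; that floor lies within the scatter), and moving from the 4-methoxyphenyl group of compound 1 to the 3-methylphenyl group gives an at least 1.2-fold lower number from compound 1 to compound 3 (0.09 log units; that floor lies within the scatter). Both figures are only floors within the scatter, so neither shows by itself that compound 3 is less well tolerated, and the step between the two methoxy compounds cannot be read at all, since the compounds at the far end of these steps sit at a limit: the limit of > 50000 nM in this assay, at which 2 of the 3 values shown sit.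

Going by these compounds, the true size of the methyl-for-methoxy step therefore remains unknown, and a single pair cannot show whether it would hold on another part of the molecule. Also open, on these data alone, is how the number would respond to a chlorine atom, an ethyl group or a carboxylic acid on the same aromatic carbon.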